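The compounds below may be only part of what the source reports. "The series", "measured", "known", "first", "only" and "open" are said of these compounds alone.

Measured compounds:
- compound 1, `CCCOCNc1n[n+]([O-])c2cc(OC)ccc2[n+]1[O-]`, with 2880 nM
- compound 2, `COc1ccc2c(c1)[n+]([O-])nc(NCOC(C)c1ccccc1)[n+]2[O-]`, with 8040 nM
- compound 3, `O=[N+]([O-])c1cccc(COCNc2n[n+]([O-])c3ccccc3[n+]2[O-])c1`, with 8540 nM

All three share the same core and differ only in the group carried on an oxygen on a saturated carbon. In a functional assay on SMMC-7721 cells (Homo sapiens) for cytotoxicity, read by MTT assay, with a stated time of 72 h (on this read-out lower numbers stand for stronger inhibition and higher numbers for weaker inhibition), compound 2 stands second highest of the three numbers. Its nearest neighbour is compound 3, whose number is higher by a margin that lies within the scatter, so no order can be read between them. Compound 1 gives a clearly lower number: the step of a 2.8-fold higher number from compound 1 to compound 2 (0.45 log units; beyond the scatter) is beyond the scatter and of modest size.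

Compound 4, `COc1ccc2c(c1)[n+]([O-])nc(NCOCc1ccccc1)[n+]2[O-]`, has not yet been measured in this assay. It differs from compound 2 by hydrogen in place of methyl on a saturated chain carbon bound to an aromatic carbon and an oxygen on a saturated carbon; cut one bond further out, the same difference reads 1-phenylethyl to benzyl. Among the measured compounds shown here, only one measured step exists, the one from compound 1 to compound 2, and it swaps propyl for 1-phenylethyl; no measured pair removes a methyl from such a carbon. With nothing that bears on this change directly, the step of a 1.1-fold lower number from compound 2 to compound 4 (0.06 log units; within the scatter) is expected to stay within the scatter, in no particular direction. For compound 4 the estimated number in this assay is 7000 nM, with a range from 2800 nM to 17000 nM.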

Compound 4, half-maximal inhibitory concentration: 21400 nM
The estimate for compound 4 lay 3.1-fold (0.49 log units) below the measured number, outside the stated range (above it).
By their numbers in this assay, from the lowest: compound 1; then compounds 2 and 3 (each within the scatter of the next); then compound 4.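

In this assay, the methyl on the saturated chain carbon bound to an aromatic carbon and an oxygen on a saturated carbon proves not to be a neutral detail: swapping it for hydrogen gives a 2.7-fold higher number from compound 2 to compound 4 (0.43 log units; beyond the scatter), so one carbon at this place is enough to move the number beyond the scatter. The wider comparison, phenyl in place of ethyl on a saturated chain carbon bound to an oxygen on a saturated carbon, gives a 7.4-fold higher number from compound 1 to compound 4 (0.87 log units; beyond the scatter), which places the benzyl compound above both the propyl compound and the 1-phenylethyl compound in this series, so adding the phenyl ring and losing the methyl both go with weaker inhibition here. Nothing available explains why these changes shift the number in this way.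

As far as these compounds go, whether the effect belongs to the methyl alone remains open, since an ethyl or a hydroxyl on that same carbon would show if other groups there hold the number down as well. From the compounds shown here alone, it also remains open how the benzyl compound would respond to an amine or a carboxylic acid on its phenyl ring.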